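Swapping the Furan for a Thiazole in Compound 1

The compounds below may be only part of what the source reports. "The series", "measured", "known", "first", "only" and "open" are said of these compounds alone.

Compound 1 `Cc1ccc(CN2CCN(c3cccc4[nH]c(-c5ccc(C(C)(C)C)cc5)nc34)CC2)o1` is the weakest binder among the three measured compounds: in an assay on isolated protein for displacement of a labelled ligand from Gonadotropin-releasing hormone receptor (Homo sapiens) (on this read-out lower numbers stand for stronger inhibition and higher numbers for weaker inhibition), compound 1 gives 705 nM. Its two measured relatives replace the 5-methylfuran-2-yl group with another small aromatic ring. Compound 2 `Cc1nc(CN2CCN(c3cccc4[nH]c(-c5ccc(C(C)(C)C)cc5)nc34)CC2)c[nH]1` carries a 2-methyl-1H-imidazol-4-yl group and in this assay compound 2 gives 7.5 nM; compound 3 `Cc1nc(C)c(CN2CCN(c3cccc4[nH]c(-c5ccc(C(C)(C)C)cc5)nc34)CC2)o1` carries a 2,4-dimethyl-1,3-oxazol-5-yl group and in this assay compound 3 gives 31 nM. The steps of a 94-fold lower number from compound 1 to compound 2 (1.97 log units; beyond the scatter) and a 23-fold lower number from compound 1 to compound 3 (1.36 log units; beyond the scatter) are both large gains, and the step of a 4.1-fold higher number from compound 2 to compound 3 (0.62 log units; beyond the scatter) places the imidazole ahead of the oxazole. Compound 4 `Cc1nc(C)c(CN2CCN(c3cccc4[nH]c(-c5ccc(C(C)(C)C)cc5)nc34)CC2)s1` makes the change (2,4-dimethyl-1,3-thiazol-5-yl in place of 5-methylfuran-2-yl on a saturated chain carbon bound to an amine nitrogen in a ring). Because a 23-fold lower number from compound 1 to compound 3 (1.36 log units; beyond the scatter) involves the ring most like this thiazole, a gain of similar size is expected for compound 4, with the larger gain of compound 2 as a more distant possibility. The expected step is an 18-fold lower number from compound 1 to compound 4 (1.25 log units; beyond the scatter). Compound 4 is therefore estimated at 40 nM in this assay. For compound 4 the estimated range runs from 10 nM to 160 nM.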

Compound 4, half-maximal inhibitory concentration: 27 nM
Beside the measured number, compound 4's estimate is 1.5-fold (0.17 log units) above it, within the range that was stated.
By their numbers in this assay, from the lowest: compound 2; then compounds 4 and 3 (each within the scatter of the next); then compound 1.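

The thiazole repeats the gain over the furan, with a 26-fold lower number from compound 1 to compound 4 (1.42 log units; beyond the scatter), so a third ring at this position, on a saturated chain carbon bound to an amine nitrogen in a ring, outperforms the 5-methylfuran-2-yl group. Exchanging the ring oxygen of the oxazole for sulfur makes no readable difference, with a 1.1-fold lower number from compound 3 to compound 4 (0.06 log units; within the scatter) lying within the scatter, while the imidazole keeps its lead, with a 3.6-fold higher number from compound 2 to compound 4 (0.56 log units; beyond the scatter). No measurement available here explains these differences in binding.

On these data alone, what a six-membered ring such as pyridine, or an open chain ending in an amine, would give at this position remains open. Every ring shown also carries at least one methyl group, and the result of replacing those methyl groups with hydrogen is unknown.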